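A few compounds are considered here, and "the series" means these few. Any claim that something is new, unique, unknown or untested is made for them only; others in the source may bear on it.

Of the compounds shown here, three built on one shared core have been measured in an assay on isolated protein for inhibition of Leucine-rich repeat serine/threonine-protein kinase 2 (Homo sapiens), read by TR-FRET and LanthaScreen, with stated times of 50 min and 30 min, in the presence of a further agent that is not named here; a lower number here means a stronger inhibitor, a higher number a weaker inhibitor. Compound 3 `C[C@@H]1CCCN1c1c(C#N)c2c(N)nc(Nc3cnn(C)c3)nc2n1C` gives 6 nM, the lowest number of the three. Compound 2 `C[C@@H]1CCCN1c1c(C#N)c2c(N)nc(Nc3cn(C)nc3Cl)nc2n1C` gives 34 nM, and compound 1 `Cc1nn(C2COC2)cc1Nc1nc(N)c2c(C#N)c(N3CCC[C@H]3C)n(C)c2n1` gives 38 nM. The steps of a 5.7-fold lower number from compound 2 to compound 3 (0.75 log units; beyond the scatter) and a 6.3-fold lower number from compound 1 to compound 3 (0.80 log units; beyond the scatter) both set compound 3 apart by more than the usual scatter, while a 1.1-fold lower number from compound 1 to compound 2 (0.05 log units; within the scatter) stays within it.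

Compound 4 `Cc1nn(C)cc1Nc1nc(N)c2c(C#N)c(N3CCC[C@H]3C)n(C)c2n1` has not yet been measured. It differs from compound 3 in one place: methyl in place of hydrogen on an aromatic carbon. In group names, 1-methyl-1H-pyrazol-4-yl becomes 1,3-dimethyl-1H-pyrazol-4-yl.

For the measured compounds named here, two measured steps bear on this. In compound 2 that aromatic carbon carries chloro, and a 5.7-fold lower number from compound 2 to compound 3 (0.75 log units; beyond the scatter) shows that replacing it with hydrogen lowered the number. In compound 1 the carbon carries methyl, with an oxetan-3-yl on the ring nitrogen, and a 6.3-fold lower number from compound 1 to compound 3 (0.80 log units; beyond the scatter) shows a similar gain when both are removed. Because a 1.1-fold lower number from compound 1 to compound 2 (0.05 log units; within the scatter) lies within the scatter, the group on the carbon rather than the group on the nitrogen appears to matter most. Putting methyl back on that carbon is therefore expected to raise the number in this assay by roughly a 4.2-fold higher number from compound 3 to compound 4 (0.62 log units; beyond the scatter). Compound 4 is expected to give 25 nM, within a range from 10 nM to 60 nM.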

Compound 4, half-maximal inhibitory concentration: 38 nM
Compound 4: middle estimate off by 1.5-fold (0.18 log units), on the low side, and the stated range covers the measured number.
By their numbers in this assay, from the lowest: compound 3; then compounds 2, 1 and 4 (each within the scatter of the next).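

In this assay, adding a single methyl to the aromatic carbon of compound 3 is now seen on its own, and this one change accounts for a loss as large as the earlier ones (a 6.3-fold higher number from compound 3 to compound 4 (0.80 log units; beyond the scatter)). Methyl and chloro on this carbon cannot be told apart (a 1.1-fold higher number from compound 2 to compound 4 (0.05 log units; within the scatter)), so among the three groups seen there, only hydrogen gives the low number. Methyl and oxetan-3-yl on the ring nitrogen also cannot be told apart (no change at the digits printed from compound 1 to compound 4 (within the scatter)), which separates the two places that differed together between compound 1 and compound 3 and ties the loss to the carbon rather than the nitrogen, at least while methyl sits on that carbon.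

No measured information explains why a group on this carbon raises the number. The compounds shown leave open how a fluoro, methoxy or amino group on that carbon would read, and whether oxetan-3-yl on the ring nitrogen would still match methyl with hydrogen on the carbon.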